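The source may hold more compounds than are shown below. What is called first, only, known or untested is meant among the compounds shown, and "the series" means these compounds.

Measured compounds:
Compound 1 `COc1ccc(C=C2C(=O)C=CC2=O)cc1`: 3800 nM
Compound 2 `O=C1C=CC(=O)C1=Cc1ccc(Cl)cc1`: 6100 nM

In an ADME assay on CCRF-CEM cells (Homo sapiens), read by XTT assay, with a stated time of 72 h (a higher number here means a weaker inhibitor, a lower number a stronger inhibitor), compound 2 stands at 6100 nM and compound 1 stands at 3800 nM, so the two values lie within the scatter of each other. Going by the values given here, compound 2 therefore has no clear separation from the only other measured compound. The next compound, compound 3 `O=C1C=CC(=O)C1=Cc1ccc(F)cc1`, keeps the shared core and carries fluoro in place of chloro on an aromatic carbon. Among the compounds with values here, one measured step bears on this change, a 1.6-fold higher number from compound 1 to compound 2 (0.21 log units; within the scatter), where chloro took the place of methoxy on an aromatic carbon. Within the data shown here, that step lies within the scatter, and it is the only guide available, since no measured compound yet carries fluoro. With so little to go on, no step beyond the scatter is expected in this assay, and no direction can be favoured with confidence. The estimate for compound 3 is 5000 nM, with an expected range from 2000 nM to 12000 nM as the outer ends. This expectation amounts to an estimated 1.2-fold lower number from compound 2 to compound 3 (0.09 log units; within the scatter) and nothing more.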

Compound 3, half-maximal inhibitory concentration: 1600 nM
Beside the measured number, compound 3's estimate is 3.1-fold (0.49 log units) above it; the whole stated range lies above it.
By their numbers in this assay, from the lowest: compound 3; then compounds 1 and 2 (each within the scatter of the next).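

Until this result, the aromatic carbon para to a group of 8 heavy atoms had shown no step beyond the scatter in this assay, as chloro and methoxy there could not be told apart. Fluoro in place of chloro now gives the first clear separation at this position (a 3.8-fold lower number from compound 2 to compound 3 (0.58 log units; beyond the scatter)), even though each group counts 1 heavy atom and neither adds a hydrogen-bond donor or acceptor. Fluoro in place of methoxy also gives a step beyond the scatter (a 2.4-fold lower number from compound 1 to compound 3 (0.38 log units; beyond the scatter)), which makes compound 3 the strongest inhibitor of the three, and nothing available explains why this position responds to the exchange.

The compounds shown leave open whether a bromo group, an amine or a carboxylic acid at the same carbon would continue this trend or reverse it, and whether a bare hydrogen there would give a number closer to that of compound 3 or to those of the other two. They also leave open whether fluoro would have a similar effect at another carbon of the aromatic ring.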